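This account rests on a few compounds, and the source may have more. Where it says the series, first, only, none or still open, it means among the compounds named here.

Among the compounds with values here, compound 3 `COc1ccc(CC(C)C(=O)N2CCN(c3ccc(C(F)(F)F)cc3[C@@H](N)CC(C)C)CC2)cc1` gives the lowest number of the three measured so far in an assay on HEK293 cells for displacement of a labelled ligand from Melanocortin receptor 4 (Homo sapiens) (on this read-out lower numbers stand for stronger inhibition and higher numbers for weaker inhibition), at 120 nM. In this assay compound 1 `COc1ccc(OCC(=O)N2CCN(c3ccc(C(F)(F)F)cc3[C@@H](N)CC(C)C)CC2)cc1` gives 3800 nM, and compound 2 `CC(C)C[C@H](N)c1cc(C(F)(F)F)ccc1N1CCN(C(=O)CSc2ccc(Cl)cc2Cl)CC1` gives 1500 nM. Compound 4 `CC(C)C[C@H](N)c1cc(C(F)(F)F)ccc1N1CCN(C(=O)COc2cccc3ccccc23)CC1` differs from compound 3 in one place: ((naphthalen-1-yl)oxy)methyl in place of 1-(4-methoxybenzyl)ethyl on a carbonyl carbon. Both steps into compound 3 bear on this change, namely a 32-fold lower number from compound 1 to compound 3 (1.50 log units; beyond the scatter) and a 13-fold lower number from compound 2 to compound 3 (1.10 log units; beyond the scatter); each brought in the 1-(4-methoxybenzyl)ethyl group and lowered the number strongly. Compound 4 removes that group again and, like compound 1, carries an aromatic ring joined through oxygen to the chain on the carbonyl carbon, so a sizeable rise in the number is expected, a 13-fold higher number from compound 3 to compound 4 (1.10 log units; beyond the scatter). Compound 4 is therefore estimated at 1500 nM, with a range from 300 nM to 6000 nM.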

Compound 4, inhibition constant: 2600 nM
Estimate against measurement, compound 4: 1.7-fold (0.24 log units) below; the range from low to high includes it.
By their numbers in this assay, from the lowest: compound 3; then compounds 2, 4 and 1 (each within the scatter of the next, the first and the last beyond it).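

In this assay, the ((naphthalen-1-yl)oxy)methyl group gives up what 1-(4-methoxybenzyl)ethyl gained on this carbonyl carbon (a 22-fold higher number from compound 3 to compound 4 (1.34 log units; beyond the scatter)). The second aromatic ring of naphthalen-1-yl recovers none of it: the change from 4-methoxyphenyl on the oxygen stays within the scatter (a 1.5-fold lower number from compound 1 to compound 4 (0.16 log units; within the scatter)), as does the change from (2,4-dichlorophenyl)sulfanyl (a 1.7-fold higher number from compound 2 to compound 4 (0.24 log units; within the scatter)). No measured evidence here explains the gap to compound 3. Still open, going by these compounds, is whether the methyl branch or the all-carbon chain of compound 3 matters more. A straight propanoyl chain ending in 4-methoxyphenyl, or naphthalen-1-yl on the branched chain, would separate these.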